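This account rests on a few compounds, and the source may have more. Where it says the series, first, only, none or still open, it means among the compounds named here.

Of the compounds shown here, two of the same shared core have been measured in an ADME assay on THP-1 cells (Homo sapiens) for cytotoxicity, read by MTT assay, tested at 50 ug/mL; a lower number here means less inhibition, a higher number more inhibition at the concentration tested (going by the name of the read-out). Compound 1 `C(=N/Nc1nc(-c2ccccc2)cs1)\c1ccc(-n2cncn2)cc1` carries a plain phenyl ring on one side of the core, and in this assay compound 1 gives 28.4%. Compound 2 `Clc1ccc(-c2csc(N/N=C/c3ccc(-n4cncn4)cc3)n2)cc1` differs from it only by a chloro in place of hydrogen on an aromatic carbon, and compound 2 gives 28.4%; the step is no change at the digits printed from compound 1 to compound 2 (within the scatter). Compound 2 therefore stands level with compound 1 on these numbers, and nothing distinguishes the two within the scatter.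

The next compound, compound 3 `O=[N+]([O-])c1ccc(-c2csc(N/N=C/c3ccc(-n4cncn4)cc3)n2)cc1`, continues from compound 2 with the change (nitro in place of chloro on an aromatic carbon). Among the compounds with values here, no measured step bears directly on this exchange: the only comparison available, from compound 1 to compound 2, concerns a different substituent at the same place and showed no movement. Within the data shown here, with that single flat step as the only guide, the expected step is a number 0.4 percentage points lower from compound 2 to compound 3 (within the scatter), that is, none beyond the scatter. Compound 3 is therefore expected to give about 28%, within a range from 15% to 45%.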

Compound 3, a percentage reported as inhibition, at one concentration (the size of the read-out at that concentration, not a potency): 12.9%
For compound 3 the middle estimate is 15.1 percentage points above the measured one; the measured number lies below the stated range.
By their numbers in this assay, from the lowest: compound 3; then compounds 1 and 2 (each within the scatter of the next).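

In this assay the place para to a large group turns out not to be indifferent to what it carries: the step of a number 15.5 percentage points lower from compound 2 to compound 3 (beyond the scatter) comes with nitro in place of chloro, and the step of a number 15.5 percentage points lower from compound 1 to compound 3 (beyond the scatter) comes with nitro in place of hydrogen. Set against the step of no change at the digits printed from compound 1 to compound 2 (within the scatter) for chloro in place of hydrogen, this shows that the flat first comparison described chloro at this place and not the place as a whole, so it could not be carried over to another group. Nothing among the data given accounts for the lower number, which stands here as an observation only.

Going by these compounds, whether the lower number belongs to nitro in particular, or would also appear with other groups on this aromatic carbon, such as an amine, a carboxylic acid or a nitrile, stays open. On these data alone, each compound is also read at a single concentration, so how inhibition by compound 3 would run at other concentrations remains open as well.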